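This account rests on a few compounds, and the source may have more. Where it says the series, first, only, none or still open, it means among the compounds named here.

Measured so far in an assay on HEK293 cells for displacement of a labelled ligand from 5-hydroxytryptamine receptor 6 (Homo sapiens), with a stated time of 60 min, tested at 0.01 uM, in the presence of a further agent that is not named here; a higher number here means a stronger effect of the compound at the concentration tested, a lower number a weaker effect:
compound 1 `COc1cc(N)c(Cl)cc1C(=O)CCC1CCN(CCNS(=O)(=O)c2ccc(N)cc2)CC1`: 7%
compound 2 `COc1cc(N)c(Cl)cc1C(=O)CCC1CCN(CCNS(=O)(=O)c2ccc(NC(C)=O)cc2)CC1`: 7%
compound 3 `COc1cc(N)c(Cl)cc1C(=O)CCC1CCN(CCNS(=O)(=O)c2cc(Br)ccc2Br)CC1`: 16%

Compound 1 stands level with compound 2 at the digits shown, the two together giving the lowest of the three numbers; compound 3 lies a number 9 percentage points higher from compound 1 to compound 3 (within the scatter), a gap that is within the scatter, so no order among the three compounds is established.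

Compound 4 `COc1ccc(S(=O)(=O)NCCN2CCC(CCC(=O)c3cc(Cl)c(N)cc3OC)CC2)cc1Br` is not yet measured. It differs from compound 1 at one place: 3-bromo-4-methoxyphenyl in place of 4-aminophenyl on a sulfonyl sulfur. The measured steps that bear on this are the two that also exchange the group on the sulfonyl sulfur, a number 9 percentage points higher from compound 1 to compound 3 (within the scatter) and a number 9 percentage points higher from compound 2 to compound 3 (within the scatter), both within the scatter; the exchange on the aromatic nitrogen, no change at the digits printed from compound 1 to compound 2 (within the scatter), concerns another part of the molecule and adds nothing on the sulfonyl side. Nothing in the measured set separates one group on the sulfonyl sulfur from another beyond the scatter. Compound 4 is therefore expected to show no step beyond the scatter in this assay, the expected step being a number 4 percentage points higher from compound 1 to compound 4 (within the scatter). The estimate for compound 4 is 11%, with a range from 0% to 26%.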

Compound 4, a percentage reported as inhibition, at one concentration (the size of the read-out at that concentration, not a potency): "not active" (no number reported)
For compound 4 the study gives words and no number; the estimate stays without a comparison.
By their numbers in this assay, from the lowest: compounds 1, 2 and 3 (each within the scatter of the next).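

Going by these compounds alone, compound 4 is reported only in words, as not active, so no step from compound 1, compound 2 or compound 3 can be read. The compounds shown leave open whether any group on the sulfonyl sulfur separates from another beyond the scatter. No evidence on this result is available.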